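Fluoro to Chloro on a Growth Inhibitor

A few compounds are considered here, and "the series" means these few. Any claim that something is new, unique, unknown or untested is made for them only; others in the source may bear on it.

In a functional assay on OVCAR-5 cells (Homo sapiens) for inhibition, read by CCK-8 assay, with a stated time of 72 h, tested at 10 uM (a higher number here means more inhibition of growth at the concentration tested, a lower number less inhibition of growth), compound 1 `CN(C)C(=O)c1cc2cnc(Nc3ccc(NC(=O)C4(C(=O)Nc5ccc(F)cc5)CC4)cc3)nc2n1C1CCCC1` gives 79.7% and compound 2 `CN(C)C(=O)c1cc2cnc(Nc3ccc(N)cn3)nc2n1C1CCCC1` gives 68%. For the measured compounds named here, compound 1 stands highest of the two numbers so far, and its gap to compound 2 lies outside the scatter. Compound 3 `CN(C)C(=O)c1cc2cnc(Nc3ccc(NC(=O)C4(C(=O)Nc5ccc(Cl)cc5)CC4)cc3)nc2n1C1CCCC1` differs from compound 1 by chloro in place of fluoro on an aromatic carbon and so turns 4-fluorophenyl into 4-chlorophenyl. Going by the values given here, no measured pair shows this swap, so a number 1.7 percentage points lower from compound 1 to compound 3 (within the scatter) is expected to be small, with no shift beyond the scatter in this assay in either direction. The estimate for compound 3 is 78% with an expected range from 64% to 90% for this single measurement.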

Compound 3, percent growth inhibition at one concentration: 85.3%
Compound 3: middle estimate off by 7.3 percentage points, on the low side, within the range that was stated.
By their numbers in this assay, from the lowest: compound 2; then compounds 1 and 3 (each within the scatter of the next).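

In this assay the swap from 4-fluorophenyl to 4-chlorophenyl gives a number 5.6 percentage points higher from compound 1 to compound 3 (within the scatter) and so shows that, at this aromatic carbon para to a large group, these two halogens cannot be told apart in growth inhibition. For the compounds shown here, this is the first reading of a change at this position, and it shows no shift beyond the scatter. Nothing measured here explains why the two read alike. The compounds shown carry only these two halogens at this position, so how a methoxy group, an amine or a carboxylic acid would read there stays open.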